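Halogen swap on the indole of a diterpenoid series

This account rests on a few compounds, and the source may have more. Where it says the series, first, only, none or still open, it means among the compounds named here.

Compound 1 `COC(=O)[C@@]1(C)CCC=C2[C@@H]1CC[C@@H](C)[C@]2(C)Cc1c[nH]c2ccc(Br)cc12` carries a bromo group on the indole ring and, in a functional assay on WiDr cells (Homo sapiens) for inhibition, read by sulforhodamine B assay, with a stated time of 48 h (a higher number here means a weaker inhibitor of growth, a lower number a stronger inhibitor of growth), compound 1 gives 20000 nM. Compound 2 `COC(=O)[C@@]1(C)CCC=C2[C@@H]1CC[C@@H](C)[C@]2(C)Cc1c[nH]c2ccc(Cl)cc12` is its chloro counterpart; in this assay compound 2 gives 20000 nM. The change between them is chloro in place of bromo on an aromatic carbon, and the step it made is no change at the digits printed from compound 1 to compound 2 (within the scatter).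

Compound 3 `COC(=O)[C@@]1(C)CCC=C2[C@@H]1CC[C@@H](C)[C@]2(C)Cc1c[nH]c2c(Br)cccc12` places the bromo group elsewhere on the indole; in this assay compound 3 gives 32000 nM. Compound 3 and compound 1 share the same atoms joined differently, and the difference between the two cores is not broken down here. Their two values are within the usual scatter of each other.

Compound 4 `COC(=O)[C@@]1(C)CCC=C2[C@@H]1CC[C@@H](C)[C@]2(C)Cc1c[nH]c2c(Cl)cccc12` is not yet measured. It differs from compound 3 by chloro in place of bromo on an aromatic carbon. This is the same kind of change as that from compound 1 to compound 2, but not the same one: around the place of the earlier change the position is meta to a fused ring and para to a fused ring, whereas here it is ortho to a fused ring and meta to a fused ring.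

The expectation for compound 4 rests on the step of no change at the digits printed from compound 1 to compound 2 (within the scatter), which showed no shift when the same kind of change was made. The step from compound 3 to compound 4 is therefore expected to be no change at the digits printed from compound 3 to compound 4 (within the scatter). Compound 4 is estimated at 32000 nM in this assay, with a range from 15000 nM to 70000 nM.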

Compound 4, concentration for 50% growth inhibition: 31000 nM
Estimate against measurement, compound 4: 1.0-fold (0.01 log units) above; the range from low to high includes it.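

Chloro in place of bromo on an aromatic carbon, here ortho to a fused ring and meta to a fused ring, gives in this assay a step of a 1.0-fold lower number from compound 3 to compound 4 (0.01 log units; within the scatter). Set beside the earlier step, the same change behaves alike on the two cores: the same change on two cores in this assay, no change at the digits printed (within the scatter) from compound 1 to compound 2 and a 1.0-fold lower number (0.01 log units; within the scatter) from compound 3 to compound 4, 1.0-fold (0.01 log units) apart, within the scatter of two such steps. This supports treating the swap of these two halogens as neutral in this assay for the four compounds shown, but it rests on only two pairs, and two steps without a shift do not show that the result would hold on other cores in the series, or say anything about how the compounds act on the cells.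

Still open, on these data alone, is whether a group other than these two halogens at the same places on the indole, such as an amine, a methoxy group or a carboxylic acid, would give a step beyond the scatter. As far as these compounds go, the rest of the shared core is equally open, including whether a carboxylic acid or an amide in place of the methyl ester, or a methyl group on the indole nitrogen, would move the growth-inhibition values.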